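Fluoro for Methoxy on an Anoctamin-2 Inhibitor Series

A few compounds are considered here, and "the series" means these few. Any claim that something is new, unique, unknown or untested is made for them only; others in the source may bear on it.

The measured compounds:
compound 1, `Cc1cc(Cl)ccc1OCc1nnc(-c2ccccc2OC(F)(F)F)o1`: in an ADME assay on cells for inhibition of anoctamin-2 (Homo sapiens), read by fluorescence, with a stated time of 20 min (on this read-out higher numbers stand for weaker inhibition and lower numbers for stronger inhibition), compound 1 gives "not active" (no number reported).
compound 2, `COc1ccccc1-c1nnc(COc2ccc(Cl)cc2C)o1`: in this assay compound 2 gives 12400 nM.
compound 3, `C/C(=N\NC(=O)COc1ccc(Cl)cc1C)c1ccccc1OC(F)(F)F`: in this assay compound 3 gives > 100000 nM, which is a limit of the assay and not a number.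

Among the three, compound 2 stands alone as the only compound with a number in this assay. Compound 3 sits at a limit, namely (the limit of > 100000 nM in this assay, at which 1 of the 3 values shown sits). Compound 1 has no number at all. Within the data shown here, no two measured compounds differ in a single place, so no measured step is available to anchor a comparison.

Compound 4, `Cc1cc(Cl)ccc1OCc1nnc(-c2ccccc2F)o1`, differs from compound 2 in one place: fluoro in place of methoxy on an aromatic carbon. The change is small in the count of heavy atoms and removes one hydrogen-bond acceptor.

With nothing measured to point to, the step from compound 2 to compound 4 is expected to be a 1.2-fold higher number from compound 2 to compound 4 (0.08 log units; within the scatter), that is, none beyond the usual scatter in this assay. Compound 4 is therefore estimated at 15000 nM in this assay, with a range from 4000 nM to 60000 nM, and a real chance that only a limit is reported.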

Compound 4, half-maximal inhibitory concentration: > 100000 nM
Compound 4: no number, only a limit; the forecaster's own chance of this, stated with the estimate: 35%; at least 6.6-fold (0.82 log units) between middle value and limit.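

With this result, the position has its first measured step: in this assay, fluoro in place of methoxy on this aromatic carbon, ortho to a large group, gives an at least 8.0-fold higher number from compound 2 to compound 4 (0.90 log units; beyond the scatter). Among these compounds, the single number in the set therefore depends on what sits at this carbon, and the change of one small group is enough to take the compound beyond the scatter and out of the measurable range. The true size of the step remains unknown because compound 4 gives only a limit of the assay and not a number, so the step marks the smallest possible loss: the limit of > 100000 nM in this assay, at which 2 of the 4 values shown sit.

The compounds shown leave open whether the loss follows the hydrogen-bond acceptor that leaves with the methoxy or some other difference between the two groups, and a single step cannot separate these readings. They also do not show how an ethoxy, a hydroxyl or an amine on this same carbon would read out, which is what could tell whether any group other than methoxy keeps a measurable value here.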